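A few compounds are considered here, and "the series" means these few. Any claim that something is new, unique, unknown or untested is made for them only; others in the source may bear on it.

Compound 1, `CCCNc1nnc(SCC(=O)N(Cc2cccc([N+](=O)[O-])c2)c2ccc(F)cc2)s1`: 241 nM
Compound 2, `CC(C)CNc1nnc(SCC(=O)N(Cc2cccc([N+](=O)[O-])c2)c2ccc(F)cc2)s1`: 1790 nM
Compound 3, `COCCNc1nnc(SCC(=O)N(Cc2cccc([N+](=O)[O-])c2)c2ccc(F)cc2)s1`: 60 nM

These three compounds share one core and differ only in the group on a nitrogen on an aromatic ring. They were tested in an assay on isolated protein for inhibition of Amine oxidase [flavin-containing] A (Homo sapiens), read by fluorescence and Amplex Red, with a stated time of 30 min; a higher number here means a weaker inhibitor, a lower number a stronger inhibitor. Compound 2 stands highest of the three numbers, that is, it is the weakest inhibitor: compound 1 lies a 7.4-fold higher number from compound 1 to compound 2 (0.87 log units; beyond the scatter) away, and compound 3 lies a 30-fold lower number from compound 2 to compound 3 (1.47 log units; beyond the scatter) away, both beyond the scatter. Compound 1 and compound 3 differ by a 4.0-fold lower number from compound 1 to compound 3 (0.60 log units; beyond the scatter).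

Compound 4, `CC(C)Nc1nnc(SCC(=O)N(Cc2cccc([N+](=O)[O-])c2)c2ccc(F)cc2)s1`, has not yet been measured in this assay. It differs from compound 2 in one place: isopropyl in place of isobutyl on a nitrogen on an aromatic ring.

Among the compounds with values here, no measured pair shows exactly this change. The closest guide is the step from compound 1 to compound 2, a 7.4-fold higher number from compound 1 to compound 2 (0.87 log units; beyond the scatter), where a methyl added to the chain of compound 1 made the number higher. Compound 4 carries a shorter chain than compound 2, so a move back toward lower numbers is expected, though with little certainty about its size. For compound 4 the expected step is a 3.0-fold lower number from compound 2 to compound 4 (0.47 log units; beyond the scatter). Compound 4 is therefore estimated at 600 nM, with a range from 150 nM to 2500 nM.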

Compound 4, half-maximal inhibitory concentration: 1070 nM
Compound 4: middle estimate off by 1.8-fold (0.25 log units), on the low side; the measured number falls inside the stated range.
By their numbers in this assay, from the lowest: compound 3; then compound 1; then compounds 4 and 2 (each within the scatter of the next).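

Trimming isobutyl to isopropyl on this nitrogen gives no readable change in potency (a 1.7-fold lower number from compound 2 to compound 4 (0.22 log units; within the scatter)), so compound 4 and compound 2 cannot be told apart. The shape of the chain counts for more here: going from the straight propyl chain to the branched isopropyl gives a clear loss (a 4.4-fold higher number from compound 1 to compound 4 (0.65 log units; beyond the scatter)), and the gap from 2-methoxyethyl is larger still (an 18-fold higher number from compound 3 to compound 4 (1.25 log units; beyond the scatter)), so among these four compounds, the two with branched chains sit at the weak end. Nothing shown explains why these chains differ in this way.

The compounds shown leave open whether a cyclopropyl or tert-butyl group on this nitrogen would fall with the branched chains. They also leave open whether a longer straight chain, or a longer chain with an ether oxygen, would keep or improve the potency of compound 3.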